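This account rests on a few compounds, and the source may have more. Where it says the series, first, only, none or still open, it means among the compounds named here.

Working notes on a series of amine-bearing amides and related carbamates and ureas on a shared core.

In an assay on NIH3T3 cells with Urotensin-2 receptor (Homo sapiens) as the target (on this read-out higher numbers stand for larger maximal responses and lower numbers for smaller maximal responses), compound 2 `Cc1cccc(C(=O)NC(CCN(C)C)c2ccc(Cl)cc2)c1C` gives 159%, the highest of the three numbers at hand. Compound 1 `CCc1ccccc1C(=O)N[C@@H](CCN(C)C)c1ccc(Cl)cc1` gives 140% in this assay, a number lower than that of compound 2 by more than the usual scatter. Compound 3 `CN(C)CCC(OC(=O)Nc1ccc(C(C)(C)C)cc1)c1ccc(Cl)cc1` gives 105% in this assay, the lowest of the three and far below compound 2, again beyond the scatter. Among the compounds with values here, compound 3 is the one measured compound that departs from the amide pattern shared by compounds 1 and 2, and it carries the smallest maximal response.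

Compound 4 `CN(C)CCC(NC(=O)NCc1ccccc1)c1ccc(Cl)cc1` has not yet been measured in this assay. Relative to compound 2 the change is: benzylamino in place of 2,3-dimethylphenyl on a carbonyl carbon. Within the data shown here, no measured pair shows this change directly, so the expectation rests on the spread seen so far. A downward step beyond the scatter is expected, estimated as a number 44 percentage points lower from compound 2 to compound 4 (beyond the scatter). For compound 4 the expected value in this assay is 115%, within a range from 85% to 145%.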

Compound 4, largest response reached (reported as efficacy), in percent of the reference or control that the assay uses: 179%
The estimate for compound 4 lay 64 percentage points below the measured number; the whole stated range lies below it.
By their numbers in this assay, from the lowest: compound 3; then compound 1; then compound 2; then compound 4.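

On a carbonyl carbon whose other neighbour is an amide-type nitrogen, benzylamino in place of 2,3-dimethylphenyl gives in this assay a number 20 percentage points higher from compound 2 to compound 4 (beyond the scatter). Within the data shown here, this is the first one-place step, and it shows that the position tolerates replacement of the aryl group directly on the carbonyl carbon without loss of maximal response. The entering group has the same heavy-atom count and the same type of aromatic ring as the group it replaces, but it brings a nitrogen and a hydrogen-bond donor. No measurement at hand bears on the reason for this rise.

This single pair cannot separate the contribution of the added nitrogen from that of losing the two methyl groups. Phenylamino and 2-phenylethylamino on the same carbonyl carbon would help to separate them and show how far the step depends on the length of the chain carrying the ring.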